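The source may hold more compounds than are shown below. What is called first, only, known or untested is meant among the compounds shown, and "the series" means these compounds.

Measured so far in an ADME assay on HepG2 cells (Homo sapiens) for cytotoxicity, read by luminescence, CellTiter-Glo and ATP content, with a stated time of 72 h; on this read-out lower numbers stand for an effect already at smaller amounts and higher numbers for an effect only at larger amounts of compound:

- compound 1, `COc1ccc(F)cc1CNCCCNc1ccnc2cc(Cc3cc(C)cc(C)c3)ccc12`, gives 940 nM
- compound 2, `COc1cccc(CNCCCNc2ccnc3cc(Oc4ccc(Cl)cc4)ccc23)c1O`, gives 5700 nM
- compound 3, `CC(C)(C)c1ccc(Oc2ccc3c(NCCCNCc4ccco4)ccnc3c2)cc1`, gives 3100 nM

Compound 2 holds the highest of the three numbers. Its gap to compound 3 lies within the usual scatter of this assay, so the two are not told apart; its gap to compound 1 lies beyond the scatter. For the measured compounds named here, no two of the measured compounds differ in one place only, so no single-point step has been measured, and the three values differ at several places of the structure at once.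

Compound 4, `COc1cccc(CNCCCNc2ccnc3cc(Oc4cccc(N(C)C)c4)ccc23)c1O`, is the next point. It differs from compound 2 in one place: 3-(dimethylamino)phenyl in place of 4-chlorophenyl on an oxygen on an aromatic ring. Going by the values given here, nothing among the measured compounds shows what a change on this oxygen does, so the step is expected to be a 1.1-fold lower number from compound 2 to compound 4 (0.06 log units; within the scatter), no movement beyond the scatter in either direction. Compound 4 is estimated at 5000 nM, with an expected range from 2000 nM to 15000 nM.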

Compound 4, half-maximal effective concentration: 7300 nM
The estimate for compound 4 lay 1.5-fold (0.16 log units) below the measured number, and the stated range covers the measured number.
By their numbers in this assay, from the lowest: compound 1; then compounds 3, 2 and 4 (each within the scatter of the next, the first and the last beyond it).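

In this assay the oxygen on an aromatic ring gains its first single-place step, where 3-(dimethylamino)phenyl in place of 4-chlorophenyl gives a 1.3-fold higher number from compound 2 to compound 4 (0.11 log units; within the scatter) and so does not tell the pair apart. In this pair, the read-out therefore does not separate an aryl group carrying chlorine from one carrying a dimethylamino group, although the entering group counts 1 hydrogen-bond acceptor and the leaving group 0. No measured property is at hand to explain this result.

A single pair leaves open whether this oxygen tolerates other exchanges in the same way, such as a phenyl ring carrying a carboxylic acid or a morpholine. Also open, on these data alone, is whether the same exchange reads alike when the amine side chain of compound 2 is replaced by that of compound 3.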